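The source may report more compounds than this note shows. Statements on the series, on what has been measured and on what is new or still open speak of the compounds shown alone.

The measured compounds:
Compound 1, `COc1ccccc1Nc1nc(-c2ccc(F)cc2)c(CC(=O)O)s1`: in an in vitro assay on COS-7 cells for displacement of a labelled ligand from prostaglandin D2 receptor 2 (Homo sapiens) (on this read-out lower numbers stand for stronger inhibition and higher numbers for weaker inhibition), compound 1 gives 1500 nM.
Compound 2, `O=C(O)Cc1sc(Nc2ccc(Cl)cc2)nc1-c1ccc(F)cc1`: in this assay compound 2 gives 960 nM.

Among the compounds with values here, compound 2 is one of only two compounds measured in this assay, and the single known step, a 1.6-fold lower number from compound 1 to compound 2 (0.19 log units; within the scatter), separates it from compound 1 by no more than the usual scatter. Compound 3, `O=C(O)Cc1sc(Cc2ccccc2)nc1-c1ccc(F)cc1`, follows from compound 2 by the change (benzyl in place of (4-chlorophenyl)amino on an aromatic carbon). This change is of a different kind from the step measured: that step exchanged one group on the nitrogen for another, whereas here the nitrogen leaves together with its group and a benzyl takes its place on the aromatic carbon. Within the data shown here, no measured step therefore bears directly on it, and the estimate rests on the starting number of compound 2 alone. Compound 3 is expected to give a somewhat higher number than compound 2 in this assay. For compound 3 the expected step is a 2.6-fold higher number from compound 2 to compound 3 (0.42 log units; beyond the scatter). Compound 3 is estimated at 2500 nM, with a wide range from 600 nM to 10000 nM.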

Compound 3, half-maximal inhibitory concentration: 140 nM
Estimate against measurement, compound 3: 18-fold (1.25 log units) above; the measured number lies below the stated range.
By their numbers in this assay, from the lowest: compound 3; then compounds 2 and 1 (each within the scatter of the next).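

In this assay, the step of a 6.9-fold lower number from compound 2 to compound 3 (0.84 log units; beyond the scatter) is larger than the usual scatter, whereas the earlier step of a 1.6-fold lower number from compound 1 to compound 2 (0.19 log units; within the scatter) is not, so this position on the five-membered ring can register a change in the number. The result also shows that the nitrogen and its hydrogen-bond donor are not needed here for a lower number, since benzyl, with no hydrogen-bond donors or acceptors, gives a lower number than (4-chlorophenyl)amino. No available evidence accounts for this difference.

The change removes the nitrogen and the chlorine together, so the compounds shown cannot assign the step to either one. A 4-chlorobenzyl group would separate the two, and a 2-phenylethyl group would test a longer chain at this position.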